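The source may hold more compounds than are shown below. What is called first, only, known or untested is meant among the compounds shown, and "the series" means these compounds.

In a functional assay on NCI-H460 cells (Homo sapiens) for cytotoxicity (a lower number here means a stronger inhibitor, a higher number a weaker inhibitor), compound 1 (`O=C(CCCCC[C@H](NC(=O)[C@@H]1CCCC(=O)N1)C(=O)Nc1ccccc1)NO`) gives 2500 nM at the digits shown. Compound 2 (`O=C(CCCCCCC(=O)Nc1cccc(C(F)(F)F)c1)NO`) gives 2500 nM in this assay and so stands level with compound 1 within the scatter. Within the data shown here, these two values are the whole measured record of the series so far, and the two compounds do not form a pair differing in one place.

Compound 3 (`Cc1cccc(NC(=O)CCCCCCC(=O)NO)c1`) has not yet been measured. It keeps the structure of compound 2 except at one place, with methyl in place of trifluoromethyl on an aromatic carbon. Among the measured compounds shown here, no measured step sizes this swap directly, and no direction can be read from the data. The expectation therefore rests on compound 2 at 2500 nM as the anchor, with the range left wide on both sides. The estimated step of no change at the digits printed from compound 2 to compound 3 (within the scatter) is expected to stay within the scatter, with no shift beyond it in either direction. For compound 3 the estimated value is 2500 nM in this assay (expected range 1000 nM to 6000 nM).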

Compound 3, half-maximal inhibitory concentration: 800 nM
Compound 3: middle estimate off by 3.1-fold (0.49 log units), on the high side; measured number below the stated range.
By their numbers in this assay, from the lowest: compound 3; then compounds 1 and 2 (each within the scatter of the next).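

In this assay, among these compounds, exchanging the trifluoromethyl group on the six-membered aromatic ring of carbon only for a methyl group gives a 3.1-fold lower number from compound 2 to compound 3 (0.49 log units; beyond the scatter), the only sized step so far. This position is therefore not silent in this assay: compound 3 reaches 800 nM, and a modest change at this one place is enough to move the number beyond the scatter. The step occurs with no change in ring count, hydrogen-bond donors, hydrogen-bond acceptors or net charge, while the group goes from 4 heavy atoms to 1, although a single pair cannot show whether heavy-atom count is what matters, and nothing available bears on why the number moves.

As far as these compounds go, whether the trend carries on at this carbon remains open, as an unsubstituted ring, a chlorine or a methoxy group could each fall on either side of methyl. Also open, from the compounds shown here alone, is whether the same swap gives a step of similar size on a longer chain or on the core of compound 1.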